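The source may report more compounds than this note shows. Statements on the series, on what has been measured and on what is new or still open speak of the compounds shown alone.

Compound 1 `CCOC(=O)c1cnc(-c2ccccc2)s1` gives no number in an assay on HEK293 cells for inhibition of transient receptor potential cation channel subfamily M member 8 (Homo sapiens), read by FLIPR, with stated times of 5 min and 3 min; on this read-out lower numbers stand for stronger inhibition and higher numbers for weaker inhibition: it sits at the limit of > 100000 nM. Compound 2 `Oc1nc(-c2cccc(F)c2)sc1-c1nn[nH]n1` also stops at the limit of > 100000 nM in this assay. Both values rest at the limit of > 100000 nM in this assay, at which 2 of the 2 values shown sit, so compound 1 stands where every value shown stands. Compound 3 `CCOC(=O)c1sc(-c2ccccc2)nc1NC(=O)C(F)(F)F` differs from compound 1 by ((trifluoromethyl)carbonyl)amino in place of hydrogen on an aromatic carbon. For the measured compounds named here, no step between measured compounds anchors this change; it is expected to give an at least 1.6-fold lower number from compound 1 to compound 3 (0.22 log units; that floor lies within the scatter), toward stronger inhibition but probably not beyond the scatter. Compound 3 is therefore estimated at 60000 nM, within 8000 nM to 200000 nM.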

Compound 3, half-maximal inhibitory concentration: 7700 nM
Compound 3: the middle estimate sits 7.8-fold (0.89 log units) above what was measured, and the stated range ends above it.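

In this assay, the aromatic carbon next to the ring nitrogen and next to the ring atom that bears an ethoxycarbonyl group tolerates substitution: ((trifluoromethyl)carbonyl)amino in place of hydrogen there gives an at least 12-fold lower number from compound 1 to compound 3 (1.11 log units; beyond the scatter). This step is a floor, and it is the first sign of inhibition among the compounds shown. Compound 1 and compound 2 stay at a limit and not a number: the limit of > 100000 nM in this assay, at which 2 of the 3 values shown sit.

On these data alone, whether the trifluoromethyl, the carbonyl or the amide hydrogen carries this step remains open. How a plain amine or an acetylamino group would compare on this carbon is also unknown, as is the effect of a carboxylic acid in place of the ethoxycarbonyl group.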